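This account rests on a few compounds, and the source may have more. Where it says the series, first, only, none or still open, it means among the compounds named here.

Measured so far in an ADME assay on Vero cells (Chlorocebus sabaeus) for cytotoxicity, read by MTT assay, with a stated time of 72 h; a lower number here means that less compound is needed, a higher number that more compound is needed for the effect:
- compound 1 `O=C(Nc1nc(-c2ccccn2)cs1)c1ccc(OCc2ccccc2)cc1` gives 2300 nM
- compound 2 `COc1ccc(C(=O)Nc2nc(-c3ccccn3)cs2)cc1` gives 9200 nM

Among the measured compounds shown here, compound 2 holds the higher of the two numbers, and compound 1 is its only neighbour. The unmeasured compound 3 `CC(=O)c1ccc(C(=O)Nc2nc(-c3ccccn3)cs2)cc1` differs from compound 2 by a single change, (acetyl in place of methoxy on an aromatic carbon), which is acetyl in place of methoxy on an aromatic carbon.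

For the measured compounds named here, only one measured step bears on this, and only indirectly. It is a 4.0-fold higher number from compound 1 to compound 2 (0.60 log units; beyond the scatter), a modest step beyond the scatter, with hydrogen in place of phenyl on a saturated chain carbon bound to an oxygen on an aromatic ring. Going by the values given here, no measured compound carries acetyl, so the data give no direction for the new change. Given the modest size of a 4.0-fold higher number from compound 1 to compound 2 (0.60 log units; beyond the scatter), a step of similar size at most is expected in this assay, and most likely none beyond the scatter. The expected step is a 1.2-fold lower number from compound 2 to compound 3 (0.06 log units; within the scatter) in this estimate. For compound 3 the estimated value is 8000 nM, with an expected range from 3000 nM to 22000 nM as its ends.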

Compound 3, half-maximal effective concentration: 10500 nM
Compound 3: middle estimate off by 1.3-fold (0.12 log units), on the low side; the measured number falls inside the stated range.
By their numbers in this assay, from the lowest: compound 1; then compounds 2 and 3 (each within the scatter of the next).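

In this assay the exchange of methoxy for acetyl on this aromatic carbon gives a 1.1-fold higher number from compound 2 to compound 3 (0.06 log units; within the scatter) and so lies within the scatter, which means that compound 2 and compound 3 cannot be told apart here even though one group is built on an ether oxygen and the other on a carbonyl. Acetyl in place of benzyloxy gives a 4.6-fold higher number from compound 1 to compound 3 (0.66 log units; beyond the scatter) in the same assay, a modest step beyond the scatter and one that stands alongside a 4.0-fold higher number from compound 1 to compound 2 (0.60 log units; beyond the scatter) from the earlier data, so of these three compounds only compound 1 stands apart from the other two. Nothing measured here offers an explanation for these numbers.

On these data alone, what remains open is whether the separation of compound 1 needs the whole benzyloxy group or would also appear with a longer chain such as butoxy, which has no phenyl ring. As far as these compounds go, it is equally open whether an amine or a carboxylic acid at this position would stay within the scatter of methoxy and acetyl or would move the number in either direction.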